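Removing One Fluorine from a Difluorophenyl Growth Inhibitor

This account rests on a few compounds, and the source may have more. Where it says the series, first, only, none or still open, it means among the compounds named here.

Compound 1 `CSc1ccc(C2=C(c3ccc(F)c(F)c3)C(=O)N3CCCC3C2)cc1`: in a functional assay on M14 cells (Homo sapiens) for cytotoxicity (a higher number here means a weaker inhibitor of growth, a lower number a stronger inhibitor of growth), it gives 300 nM.
Compound 2 `CSc1ccc(C2=C(c3ccc(O)cc3)C(=O)N3CCCC3C2)cc1`: in this assay compound 2 gives only a limit, > 100000 nM.

Among the two values shown, compound 1 carries the only definite number; the other value is a limit. Going by the values given here, the single measured step is an at least 330-fold higher number from compound 1 to compound 2 (2.52 log units; beyond the scatter), which ends at the limit of > 100000 nM in this assay, at which 1 of the 2 values shown sits.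

Compound 3 `CSc1ccc(C2=C(c3ccc(F)cc3)C(=O)N3CCCC3C2)cc1` has not been measured. It differs from compound 1 by hydrogen in place of fluoro on an aromatic carbon.

The measured step concerns the exchange of the whole ring for a 4-hydroxyphenyl group, not the loss of a single fluoro, so it bears on the new step only loosely. Since compound 3 keeps the fluoro group and the rest of the core of compound 1, a step in this assay within or slightly beyond the scatter is expected, toward a somewhat higher number. Compound 3 is therefore estimated at 500 nM, within 150 nM to 2500 nM, which corresponds to an expected step of a 1.7-fold higher number from compound 1 to compound 3 (0.22 log units; within the scatter).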

Compound 3, concentration for 50% growth inhibition: 600 nM
Beside the measured number, compound 3's estimate is 1.2-fold (0.08 log units) below it, within the range that was stated.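

In this assay, hydrogen in place of the fluoro group gives a 2.0-fold higher number from compound 1 to compound 3 (0.30 log units; within the scatter), so compound 1 and compound 3 cannot be told apart, and this fluoro group can go without a change beyond the scatter. The remaining fluoro group behaves differently: fluoro in place of hydroxy on an aromatic carbon gives an at least 160-fold lower number from compound 2 to compound 3 (2.22 log units; beyond the scatter), and as this is a change in one place, the large gap between compound 1 and compound 2 goes with the hydroxy group and not with the loss of the other fluoro group. The value of compound 2 is a limit and not a number: the limit of > 100000 nM in this assay, at which 1 of the 3 values shown sits.

The compounds shown leave open whether a plain phenyl ring, with hydrogen at the remaining fluoro position, would hold up as compound 3 does. They also leave open how a methoxy group, a chlorine or an amine would fare at that same place.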